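This account rests on a few compounds, and the source may have more. Where it says the series, first, only, none or still open, it means among the compounds named here.

Measured so far:
- Compound 1 `CN(C)c1ccc(/C=C(/SCc2ccc(Cl)cc2Cl)C(=O)c2ccc(Cl)cc2)cc1`: 50000 nM
- Compound 2 `CN(C)c1ccc(/C=C(/SCc2ccc(F)cc2)C(=O)c2ccc(Br)cc2)cc1`: 50000 nM
- Compound 3 `COc1ccc(/C=C(/SCc2ccc(Cl)cc2)C(=O)c2ccc(Br)cc2)cc1`: 10000 nM

In a functional assay on DU-145 cells (Homo sapiens) for inhibition, read by trypan blue exclusion, with a stated time of 96 h (a lower number here means a stronger inhibitor of growth, a higher number a weaker inhibitor of growth), compound 2 gives 50000 nM, level with compound 1 at the digits shown; the two share the highest number of the three. Compound 3 sits furthest away with a lower number, a gap that lies beyond the usual scatter. Compound 4 `Cc1ccsc1/C=C(/SCc1ccc(F)cc1)C(=O)c1ccc(Br)cc1` differs from compound 2 in one place: 3-methylthiophen-2-yl in place of 4-(dimethylamino)phenyl on a double-bonded chain carbon bound to a double-bonded chain carbon. Among the measured compounds shown here, no step between measured compounds tells how this change moves the number, so the expectation rests on compound 2 alone. The step of no change at the digits printed from compound 2 to compound 4 (within the scatter) is expected to be small, without a clear direction beyond the scatter. Compound 4 is estimated at 50000 nM in this assay, within a range from 15000 nM to 100000 nM.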

Compound 4, concentration for 50% growth inhibition: 50000 nM
For compound 4 middle estimate and measured number coincide at the digits printed; low and high end bracket the measured number.
By their numbers in this assay, from the lowest: compound 3; then compounds 1, 2 and 4 (each within the scatter of the next).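

In this assay, putting 3-methylthiophen-2-yl in place of 4-(dimethylamino)phenyl gives no change at the digits printed from compound 2 to compound 4 (within the scatter). Among the compounds shown here, this is the first direct comparison at this position, and it shows that the number does not depend on keeping the six-membered carbon ring or its nitrogen. No measurement here explains why the two groups read alike.

On these data alone, whether a pyridine ring or a carboxylic acid at this position would move the number stays open. For the compounds shown here, compound 3 differs from both compounds in more than one place, so no step to it can be read.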